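Removing a Ring Methyl from Two Related Cores

This account rests on a few compounds, and the source may have more. Where it says the series, first, only, none or still open, it means among the compounds named here.

Measured compounds:
Compound 1, `CCCCc1cc(OC)c2c(C)cc(C)c(C)c2c1OC(C)=O`, gives 11900 nM in a functional assay for inhibition, with Rattus norvegicus as the target; a higher number here means a weaker inhibitor, a lower number a stronger inhibitor.
Compound 2, `CCCCc1cc(OC)c2c(C)ccc(C)c2c1OC(C)=O`, gives 7350 nM in this assay.
Compound 3, `CCCCc1c(C)c(OC)c2c(ccn2C)c1OC(C)=O`, gives 760 nM in this assay.

Compound 1 and compound 2 share a core and differ in one place: hydrogen in place of methyl on an aromatic carbon. The step was a 1.6-fold lower number from compound 1 to compound 2 (0.21 log units; within the scatter). Compound 3 rests on a different core; the difference between the two cores is not broken down here. Compound 3 gives the lowest number of the three, with both other compounds lying beyond the scatter above it.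

Compound 4, `CCCCc1cc(OC)c2c(ccn2C)c1OC(C)=O`, has not yet been measured. It differs from compound 3 by hydrogen in place of methyl on an aromatic carbon. Among the measured compounds shown here, this is the same kind of change as the one between compound 1 and compound 2, though the surroundings differ: in compound 3 the carbon is ortho to a butyl group, ortho to a methoxy group and meta to an acetoxy group, whereas in compound 1 it is ortho to a methyl group and meta to a methyl group. Because the earlier step of a 1.6-fold lower number from compound 1 to compound 2 (0.21 log units; within the scatter) stayed within the scatter, a similarly small step is expected here, a 1.3-fold lower number from compound 3 to compound 4 (0.10 log units; within the scatter). Compound 4 is therefore estimated at 600 nM, with a likely range from 250 nM to 1500 nM.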

Compound 4, half-maximal inhibitory concentration: 720 nM
Beside the measured number, compound 4's estimate is 1.2-fold (0.08 log units) below it, and the stated range covers the measured number.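

Swapping the ring methyl for hydrogen on the core of compound 3 gave a 1.1-fold lower number from compound 3 to compound 4 (0.02 log units; within the scatter) in this assay, so this measurement cannot tell the two compounds apart. Set beside the earlier pair, the same swap gives steps on the two cores that cannot be told apart either: the same change on two cores in this assay, a 1.6-fold lower number (0.21 log units; within the scatter) from compound 1 to compound 2 and a 1.1-fold lower number (0.02 log units; within the scatter) from compound 3 to compound 4, 1.5-fold (0.19 log units) apart, within the scatter of two such steps. This shows that, on these two cores, the methyl can go without a step beyond the scatter, but two pairs do not show that the same would hold on every core in the series, and they do not explain why the number for the core of compound 3 stands apart from those of the other core.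

As far as these compounds go, all four compounds carry a butyl chain, a methoxy group and an acetoxy group, so it remains open what a longer chain in place of the butyl, or a free hydroxyl or an amine in place of the acetoxy group, would do. Also open, from the compounds shown here alone, is what an ethyl group or a chlorine atom would do on the aromatic carbon that holds the methyl.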